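A few compounds are considered here, and "the series" means these few. Any claim that something is new, unique, unknown or untested is made for them only; others in the source may bear on it.

Of the compounds shown here, three sharing one core have been measured in a functional assay on the whole organism (strain Sprague-Dawley) for inhibition, with Rattus norvegicus as the target, with a stated time of 10 min; a higher number here means that more compound is needed for the effect, a lower number that less compound is needed. Compound 1 `CCOC(=O)c1cnc(-c2cc(OC)ccc2OCC)[nH]c1=O` gives 0.3 mg/kg, compound 2 `CCOC(=O)c1ccc(OCC)c(-c2ncc(C(=O)OCC)c(=O)[nH]2)c1` gives 1 mg/kg, and compound 3 `CCOC(=O)c1cnc(-c2cc([N+](=O)[O-])ccc2OCC)[nH]c1=O` gives 5 mg/kg, the highest number of the three, so it needs the most compound for the effect. Compound 4 `CCOC(=O)c1cnc(-c2cc(S(N)(=O)=O)ccc2OCC)[nH]c1=O` differs from compound 3 in one group, with sulfamoyl in place of nitro on an aromatic carbon. For the measured compounds named here, no measured compound carries sulfamoyl, so the nearest guides are the steps that brought in nitro. Nitro replacing methoxy gave a 17-fold higher number from compound 1 to compound 3 (1.22 log units; beyond the scatter), and nitro replacing ethoxycarbonyl gave a 5.0-fold higher number from compound 2 to compound 3 (0.70 log units; beyond the scatter). Both steps point upward, so removing nitro is expected to lower the number modestly in this assay, though this remains uncertain. The expected change is a 2.5-fold lower number from compound 3 to compound 4 (0.40 log units; beyond the scatter). For compound 4 the estimated value is 2 mg/kg, within an expected range from 0.4 mg/kg to 8 mg/kg.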

Compound 4, dose for 50% inhibition: 50 mg/kg
Estimate against measurement, compound 4: 25-fold (1.40 log units) below; the measured number lies above the stated range.
By their numbers in this assay, from the lowest: compound 1; then compound 2; then compound 3; then compound 4.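

In this assay nitro does not mark the top of the range at this position, para to an ethoxy group: sulfamoyl gives a 10-fold higher number from compound 3 to compound 4 (1.00 log units; beyond the scatter) and a 50-fold higher number from compound 2 to compound 4 (1.70 log units; beyond the scatter) and also a 170-fold higher number from compound 1 to compound 4 (2.22 log units; beyond the scatter) in a single change each. Of the groups compared here, only sulfamoyl carries a hydrogen-bond donor, but one compound cannot link the rise to that donor. No measurement at hand explains the rise. Still open, on these data alone, is where an amine or a carboxylic acid would fall at this position, and whether a sulfamoyl group with a methyl on its nitrogen would behave like sulfamoyl itself.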